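Dichloro for fluoro on the azetidinone aryl ring

The source may hold more compounds than are shown below. What is called first, only, known or untested is meant among the compounds shown, and "the series" means these compounds.

Compound 1: `COC(=O)/C(=C/c1ccccc1)CN1C(=O)[C@@H](OC)[C@H]1c1ccccc1` — recorded only as "not toxic" (no number reported), with no number given.
Compound 2: `COC(=O)/C(=C/c1ccccc1)CN1C(=O)[C@@H](OC)[C@H]1c1ccc(F)cc1` — 27900 nM

Two compounds share a common core and differ only in the aromatic ring attached to the saturated ring carbon. Within the data shown here, in an ADME assay on cells (Epithelial cell, Homo sapiens) for antiproliferative activity, read by MTT assay, with a stated time of 48 h (on this read-out higher numbers stand for weaker inhibition and lower numbers for stronger inhibition), compound 2 gives 27900 nM; this is the only number reported, since compound 1 was described simply as "not toxic" (no number reported) without a figure. Compound 2 therefore stands alone as the reference point, and its inhibition is weak.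

Compound 3, `COC(=O)/C(=C/c1ccccc1)CN1C(=O)[C@@H](OC)[C@H]1c1ccc(Cl)cc1Cl`, carries 2,4-dichlorophenyl in place of 4-fluorophenyl on a saturated ring carbon. Among the measured compounds shown here, no measured step between two numbered compounds exists to calibrate this change, so the expectation rests on the weak reading of compound 2 alone. A modest shift toward stronger inhibition, or none beyond the scatter, is expected. For compound 3 the estimated value is 15000 nM, within a range of 5000 nM to 60000 nM, which corresponds to an expected step of a 1.9-fold lower number from compound 2 to compound 3 (0.27 log units; within the scatter).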

Compound 3, half-maximal inhibitory concentration: 70000 nM
Estimate against measurement, compound 3: 4.7-fold (0.67 log units) below; measured number above the stated range.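

In this assay replacing 4-fluorophenyl with 2,4-dichlorophenyl on the saturated ring carbon gives a 2.5-fold higher number from compound 2 to compound 3 (0.40 log units; beyond the scatter) and so moves the read-out toward weaker inhibition, not stronger. Among these compounds, the step is modest, yet it is the first measured sign that the aromatic group on this carbon can shift the result; compound 1 carries no number, so its steps cannot be read. No measurement shown accounts for this shift.

The fluorine leaves and two chlorines enter in a single change, so the compounds shown cannot separate the loss of fluorine from the effect of either chlorine. As far as these compounds go, whether an amine or a carboxylic acid on that phenyl ring would move the number toward stronger inhibition also remains open.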